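Replacing a nitrile with two fluorines on the phenyl

A few compounds are considered here, and "the series" means these few. Any claim that something is new, unique, unknown or untested is made for them only; others in the source may bear on it.

In a functional assay for agonist activity at G protein-coupled receptor 88 (Homo sapiens), read by HTRF and cAMP accumulation (on this read-out higher numbers stand for an effect only at larger amounts of compound and lower numbers for an effect already at smaller amounts), compound 3 `CC[C@H](C)[C@H](N)CN(C(=O)[C@@H]1C[C@H]1c1cccc(C#N)c1)c1ccc(-c2ccccc2)cc1` gives 1600 nM, the highest of the two single numbers. Its nearest neighbour, compound 2 `CC[C@H](C)[C@H](N)CN(C(=O)[C@@H]1C[C@H]1c1cccc(F)c1)c1ccc(-c2ccccc2)cc1`, gives 560 nM, and compound 1 `CC[C@H](C)[C@H](N)CN(C(=O)[C@@H]1C[C@H]1c1ccccc1)c1ccc(-c2ccccc2)cc1` gives 230 nM; 800 nM (2 entries) across repeated runs (the several entries of compound 1 in this assay, 230 nM; 800 nM (2 entries)). Among the compounds with values here, the only measured change at this spot is the step of a 2.9-fold higher number from compound 2 to compound 3 (0.46 log units; beyond the scatter), a cyano replacing a fluoro on the aromatic carbon. Compound 4 `CC[C@H](C)[C@H](N)CN(C(=O)[C@@H]1C[C@H]1c1cc(F)ccc1F)c1ccc(-c2ccccc2)cc1` differs from compound 3 by 2,5-difluorophenyl in place of 3-cyanophenyl on a saturated ring carbon. Because compound 2 gives 560 nM with a single fluorine, a ring carrying two fluorines and no nitrile is expected to sit nearer compound 2 than compound 3, a modest move toward smaller amounts. Compound 4 is therefore estimated at 700 nM, within a range from 250 nM to 2000 nM. The expected step of a 2.3-fold lower number from compound 3 to compound 4 (0.36 log units; beyond the scatter) is modest in size.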

Compound 4, half-maximal effective concentration: 770 nM
The estimate for compound 4 lay 1.1-fold (0.04 log units) below the measured number; low and high end bracket the measured number.
By their numbers in this assay, from the lowest: compounds 2 and 4 (each within the scatter of the next); then compound 3.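

Swapping 3-cyanophenyl for 2,5-difluorophenyl on this saturated ring carbon brings a 2.1-fold lower number from compound 3 to compound 4 (0.32 log units; beyond the scatter) in this assay and so moves the number back toward that of the singly fluorinated ring. Adding the second fluorine gives a 1.4-fold higher number from compound 2 to compound 4 (0.14 log units; within the scatter) and thus no readable change. Nothing in the data explains why these groups differ.

Still open, on these data alone, is whether a methoxy group, a trifluoromethyl group or an amine on this phenyl would bring the number lower than the fluorinated rings do.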